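Removing the nitro from the benzoyl ring of compound 1

The compounds below may be only part of what the source reports. "The series", "measured", "known", "first", "only" and "open" are said of these compounds alone.

Measured compounds:
- compound 1 `CC(/C=N/Nc1ccc([N+](=O)[O-])cc1)=N\NC(=O)c1ccc([N+](=O)[O-])cc1`: 980 nM
- compound 2 `CC(/C=N/Nc1ccc([N+](=O)[O-])cc1)=N\NC(=O)c1ccccc1N`: 4900 nM
- compound 3 `CC(/C=N/Nc1ccc([N+](=O)[O-])cc1)=N\NC(=O)c1ccccc1O`: 1640 nM

All three were tested in a functional assay on cells (Splenocyte, Mus musculus, strain BALB/c) for inhibition, read by scintillation counting and thymidine incorporation, with a stated time of 72 h; a lower number here means a stronger inhibitor, a higher number a weaker inhibitor. Compound 1 gives the lowest number of the three; compound 3 sits nearest, within the scatter a 1.7-fold higher number from compound 1 to compound 3 (0.22 log units; within the scatter), while compound 2 is furthest a 5.0-fold higher number from compound 1 to compound 2 (0.70 log units; beyond the scatter). Between the two substituted phenyl analogues the step of a 3.0-fold lower number from compound 2 to compound 3 (0.48 log units; beyond the scatter) is modest.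

Compound 4 `CC(/C=N/Nc1ccc([N+](=O)[O-])cc1)=N\NC(=O)c1ccccc1` is not yet measured. It differs from compound 1 at one point, (hydrogen in place of nitro on an aromatic carbon). For the measured compounds named here, the steps that bear on this are those in which the 4-nitrophenyl on the carbonyl carbon was exchanged: the step of a 5.0-fold higher number from compound 1 to compound 2 (0.70 log units; beyond the scatter) and the step of a 1.7-fold higher number from compound 1 to compound 3 (0.22 log units; within the scatter). Both moved the number upward, one modestly, one within the scatter. Going by the values given here, no measured step removes a nitro for a hydrogen alone.

The expectation for compound 4 is therefore a small rise, estimated as a 1.8-fold higher number from compound 1 to compound 4 (0.26 log units; within the scatter). Compound 4 is expected to give about 1800 nM, with a range from 800 nM to 4500 nM.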

Compound 4, half-maximal inhibitory concentration: > 12000 nM
Compound 4: only a limit was reported; the forecaster's own chance of this, stated with the estimate: 5%; middle value at least 6.6-fold (0.82 log units) from the limit.
By their numbers in this assay, from the lowest: compounds 1 and 3 (each within the scatter of the next); then compound 2. At a limit, above all of these: compound 4.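

The reading for compound 4 is a limit and not a number: the limit of > 12000 nM in this assay, at which 1 of the 4 values shown sits. Read against it, the unsubstituted phenyl does not behave as a neutral baseline at this ring, with an at least 12-fold higher number from compound 1 to compound 4 (1.08 log units; beyond the scatter), an at least 7.3-fold higher number from compound 3 to compound 4 (0.86 log units; beyond the scatter) and an at least 2.4-fold higher number from compound 2 to compound 4 (0.38 log units; beyond the scatter). Nitro, hydroxy and amino all give lower numbers than hydrogen, so the earlier exchanges, which only compared substituted rings, hid how much this series depends on carrying a group on the benzoyl ring.

On these data alone, how far compound 4 actually lies past its limit stays unknown, so these three steps give only minimum sizes. Also open, as far as these compounds go, is whether a chloro, a methoxy or a carboxylic acid in place of nitro would keep the number of compound 1, or whether nitro itself is required.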